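Cytotoxicity ceiling in the amide series; tolyl analogue pending

The source may hold more compounds than are shown below. What is called first, only, known or untested is meant among the compounds shown, and "the series" means these compounds.

Of the compounds shown here, three of the shared core have been measured in a toxicity assay on THP-1 cells (Homo sapiens) for inhibition; a lower number here means that less compound is tolerated, a higher number that more compound is tolerated. Compound 1 `COc1ccc(-c2cn(C)c(NC(=O)c3ccc(F)cc3)n2)cc1` returns only a limit of the assay, > 50000 nM. Compound 3 `Cn1c(-c2ccc([N+](=O)[O-])cc2)cnc1NC(=O)c1ccc(F)cc1` likewise gives only a limit, > 50000 nM. Compound 2 `COc1ccc(-c2cnc(NC(=O)c3ccco3)n2C)cc1`, the starting point for the step considered here, also gives a limit rather than a number, > 100000 nM. Compound 2 therefore stands with the other two at the tolerated end of this assay: no numerical value exists for any of the three, compound 2 sitting at the limit of > 100000 nM in this assay, at which 1 of the 3 values shown sits, and compounds 1 and 3 at the limit of > 50000 nM in this assay, at which 2 of the 3 values shown sit. For the measured compounds named here, no step between measured compounds can be computed; every value is a limit.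

Compound 4 `COc1ccc(-c2cnc(NC(=O)c3ccc(C)cc3)n2C)cc1` differs from compound 2 in one place: 4-methylphenyl in place of furan-2-yl on a carbonyl carbon. The measured set offers no instance in which a change of the amide aryl group moved this assay off its limit; all three values sit at a ceiling. The expected step is an at least 1.2-fold lower number from compound 2 to compound 4 (0.09 log units; that floor lies within the scatter), which means none beyond the scatter, with a limit again the most likely outcome. Compound 4 is estimated at 80000 nM in this assay, with a range from 30000 nM to 200000 nM.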

Compound 4, half-maximal cytotoxic concentration: > 100000 nM
Compound 4: a limit, no number; the forecaster's own chance of this, stated with the estimate: 80%; middle value at least 1.2-fold (0.09 log units) away from the limit.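

In this assay no step can be read from compound 2 to compound 4, as both give only a limit of the assay: the limit of > 100000 nM in this assay, at which 2 of the 4 values shown sit.

The compounds shown leave open what concentration lies behind each limit, and whether any change of the group on the carbonyl carbon would yield an actual number in this assay.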